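Swapping the Thiophene Attachment Point on a Dihydropyrimidinone Ester

The source may report more compounds than this note shows. Statements on the series, on what has been measured and on what is new or still open speak of the compounds shown alone.

Of the compounds shown here, three sharing one core have been tested in an assay on membranes from CHO cells for displacement of a labelled ligand from adenosine receptor A1 (Homo sapiens), read by scintillation counting, with a stated time of 60 min, tested at 1 uM; a higher number here means more inhibition at the concentration tested (going by the name of the read-out), a lower number less inhibition. Compound 1 `COC(=O)C1=C(C)NC(=O)NC1c1cccs1` gives 6%. Compound 2 `CCCOC(=O)C1=C(C)NC(=O)NC1c1cccs1` gives 43%, and compound 3 `CC1=C(C(=O)OCc2ccccc2)C(c2cccs2)NC(=O)N1` gives 45%. The steps of a number 37 percentage points higher from compound 1 to compound 2 (beyond the scatter) and a number 39 percentage points higher from compound 1 to compound 3 (beyond the scatter) both lie beyond the scatter, whereas a number 2 percentage points higher from compound 2 to compound 3 (within the scatter) does not. Compound 3 therefore shows the highest number of the three, but compound 2 sits within the scatter of it, so the two cannot be ordered; only compound 1 stands clearly apart.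

Compound 4 `CC1=C(C(=O)OCc2ccccc2)C(c2ccsc2)NC(=O)N1` differs from compound 3 as follows: thiophen-3-yl in place of thiophen-2-yl on a saturated ring carbon. None of the three measured steps touches this part of the molecule; all of them alter the ester side. For the measured compounds named here, no measured step therefore bears on this change, and there is no basis for expecting a shift beyond the scatter in this assay. The step from compound 3 to compound 4 is expected to be a number 3 percentage points lower from compound 3 to compound 4 (within the scatter). Compound 4 is accordingly estimated at 42%, within a range of 22% to 62%.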

Compound 4, a percentage reported as inhibition, at one concentration (the size of the read-out at that concentration, not a potency): 57%
Beside the measured number, compound 4's estimate is 15 percentage points below it, and the stated range covers the measured number.
By their numbers in this assay, from the lowest: compound 1; then compounds 2 and 3 (each within the scatter of the next); then compound 4.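

For the compounds shown here, all the earlier steps changed the ester side, so they said nothing about the ring on the saturated ring carbon of the shared core. In this assay, the step is a number 12 percentage points higher from compound 3 to compound 4 (beyond the scatter), which shows that this position responds to how the thiophene is attached, even though thiophen-2-yl and thiophen-3-yl have the same atoms and the same counts of donors and acceptors. Nothing available explains why moving the attachment point changes the number.

On these data alone, it remains open whether thiophen-3-yl would give a similar step alongside the esters of compound 1 and compound 2, where the thiophen-2-yl compounds differ widely. As far as these compounds go, it is also open how other rings at this carbon, such as a pyridine or a furan, would compare with either thiophene.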